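Chlorinated Aryl Thioether as a Variant of Compound 1

A few compounds are considered here, and "the series" means these few. Any claim that something is new, unique, unknown or untested is made for them only; others in the source may bear on it.

Measured compounds:
- compound 1 `O=C(O)Cn1c(SCCc2ccccc2)nc2ccccc21`: 881 nM
- compound 2 `CCOC(=O)CCCCCSc1nc2ccccc2n1CC(=O)O`: 1010 nM

In an assay on HEK293 cells for displacement of a labelled ligand from prostaglandin D2 receptor 2 (Homo sapiens) (on this read-out higher numbers stand for weaker inhibition and lower numbers for stronger inhibition), compound 1 gives 881 nM, the lowest of the two numbers recorded, and compound 2 gives 1010 nM, the nearest to it. For the measured compounds named here, the only measured step, a 1.1-fold higher number from compound 1 to compound 2 (0.06 log units; within the scatter), swaps the group at the far end of the chain from the sulfur and leaves the read-out essentially unchanged.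

Compound 3 `O=C(O)Cn1c(SCc2ccccc2Cl)nc2ccccc21` has not yet been measured in this assay. It differs from compound 1 as follows: 2-chlorophenyl in place of benzyl on a saturated chain carbon bound to a sulfur. Going by the values given here, this change sits on the chain carbon bound to the sulfur, a different place from the one probed by the step from compound 1 to compound 2, so no measured step speaks to it directly. What the data do show is that the group beyond the sulfur tolerated a large swap without a shift beyond the scatter. On that basis a small step, a 1.3-fold lower number from compound 1 to compound 3 (0.10 log units; within the scatter), is expected, in no firm direction. Compound 3 is therefore estimated at 700 nM, with a range from 250 nM to 2000 nM.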

Compound 3, half-maximal inhibitory concentration: 370 nM
Compound 3: middle estimate off by 1.9-fold (0.28 log units), on the high side; the measured number falls inside the stated range.
By their numbers in this assay, from the lowest: compound 3; then compounds 1 and 2 (each within the scatter of the next).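

In this assay, for the compounds shown here, the swap of benzyl for 2-chlorophenyl on a saturated chain carbon bound to a sulfur gives a 2.4-fold lower number from compound 1 to compound 3 (0.38 log units; beyond the scatter) and is the first step in this small set to lie beyond the scatter, so the group at this place can move the number, though only modestly. The simple counts show how little separates the two groups: each has 7 heavy atoms, one six-membered aromatic ring of carbon only, no hydrogen-bond donors or acceptors and no net charge, while the entering group holds a chlorine and the leaving group holds only carbon in its heavy-atom count. No measurement at hand bears on why the number falls.

The swap changes the whole group at once, so the compounds shown cannot separate the contribution of the chlorine from that of the rest of the change; an unsubstituted phenyl at the same place would be the direct comparison. They also leave open whether a bromine in place of the chlorine, or an amine on this group, would lower the number further, leave it unchanged or raise it.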